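Three Limits and a Fluorophenyl Substitution

The source may report more compounds than this note shows. Statements on the series, on what has been measured and on what is new or still open speak of the compounds shown alone.

Compound 1 `O=C(/C=C\c1cccc(O)c1)N1N=C(c2ccncc2)OC1c1c[nH]c2ccccc12` in an ADME assay on HeLa cells (Homo sapiens) for cytotoxicity, read by MTT assay, with a stated time of 72 h (on this read-out lower numbers stand for stronger inhibition of growth and higher numbers for weaker inhibition of growth), gives > 30 ug/mL, which is a limit of the assay and not a number.
Compound 2 `O=C(/C=C\c1ccccc1[N+](=O)[O-])N1N=C(c2ccncc2)OC1c1c[nH]c2ccccc12` in this assay gives > 30 ug/mL, again only a limit.
Compound 3 `O=C(/C=C\c1ccc([N+](=O)[O-])cc1)N1N=C(c2ccncc2)OC1c1c[nH]c2ccccc12` in this assay gives > 30 ug/mL, also a limit.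

Within the data shown here, compound 3 thus stands at the same limit as its two companions: the limit of > 30 ug/mL in this assay, at which 3 of the 3 values shown sit, sums up the whole set, and no measured compound yields a number. The steps a step that the two limits leave unreadable from compound 1 to compound 2, a step that the two limits leave unreadable from compound 1 to compound 3 and a step that the two limits leave unreadable from compound 2 to compound 3 all run between two limits and cannot be read in size or direction.

Compound 4 `O=C(/C=C\c1cccc(F)c1)N1N=C(c2ccncc2)OC1c1c[nH]c2ccccc12` has not yet been measured. Its difference from compound 3 is 3-fluorophenyl in place of 4-nitrophenyl on a double-bonded chain carbon bound to a double-bonded chain carbon. Among the measured compounds shown here, no measured step bears readably on this change, so no size or direction can be drawn from them for this assay; the three limits show only that exchanging the aryl group on this chain carbon has not brought any of compounds 1, 2 or 3 into the measured range. Compound 4 is therefore expected to sit near the same limit, an estimated 35 ug/mL with a range of 12 ug/mL to 100 ug/mL. The step that the limit leaves unreadable from compound 3 to compound 4 is expected to be none beyond the scatter.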

Compound 4, concentration for 50% growth inhibition: > 30 ug/mL
Compound 4 gave a limit, no number (the forecaster's own chance of this, stated with the estimate: 75%); the middle value is on the limit's open side.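

In this assay compound 4 gives > 30 ug/mL, which is a limit and not a number. The steps joining compound 4 to compound 1, compound 2 and compound 3 all run between limits and cannot be read in size or direction. The compounds shown leave open how strongly any of them inhibits growth, and whether any other aryl group on this chain carbon gives a measured number: the limit of > 30 ug/mL in this assay, at which 4 of the 4 values shown sit.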